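A few compounds are considered here, and "the series" means these few. Any claim that something is new, unique, unknown or untested is made for them only; others in the source may bear on it.

Compounds measured in a functional assay on HeLa cells (Homo sapiens) for antiproliferative activity; a lower number here means a stronger inhibitor, a higher number a weaker inhibitor:
compound 1, `C/C(=N\Nc1nc(-c2ccc(C)cc2)cs1)c1cc2ccccc2o1`, 14300 nM
compound 2, `COc1ccc(-c2csc(N/N=C(\C)c3cc4ccccc4o3)n2)cc1`, 18700 nM
compound 3, `CCOC(=O)Cc1csc(N/N=C(\C)c2cc3ccccc3o2)n1`, 9260 nM

Compound 2 stands at the top of these three numbers. The step of a 1.3-fold higher number from compound 1 to compound 2 (0.12 log units; within the scatter) lies within the scatter, so compounds 1 and 2 cannot be told apart, whereas the step of a 2.0-fold lower number from compound 2 to compound 3 (0.31 log units; beyond the scatter) is modest but beyond it.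

Compound 4, `C/C(=N\Nc1nc(C)cs1)c1cc2ccccc2o1`, has not yet been measured. It differs from compound 2 in one place: methyl in place of 4-methoxyphenyl on an aromatic carbon. The measured steps that bear on this are the two in which the aryl group on that carbon is replaced by something smaller, a 1.5-fold lower number from compound 1 to compound 3 (0.19 log units; within the scatter) and a 2.0-fold lower number from compound 2 to compound 3 (0.31 log units; beyond the scatter). Both move the number downward, one within and one just beyond the scatter. Among the measured compounds shown here, a methyl is an even smaller replacement than the (ethoxycarbonyl)methyl of compound 3, and no measured step shows what a methyl at this place does. On this basis a small downward step is expected, a 1.6-fold lower number from compound 2 to compound 4 (0.19 log units; within the scatter), though it may well stay within the scatter. Compound 4 is therefore estimated at 12000 nM in this assay, with a range from 6000 nM to 25000 nM.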

Compound 4, half-maximal inhibitory concentration: 8970 nM
The estimate for compound 4 lay 1.3-fold (0.13 log units) above the measured number; measured number inside the range.
By their numbers in this assay, from the lowest: compounds 4, 3, 1 and 2 (each within the scatter of the next, the first and the last beyond it).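

In this assay, methyl in place of 4-methoxyphenyl on the aromatic carbon next to the ring nitrogen gives a 2.1-fold lower number from compound 2 to compound 4 (0.32 log units; beyond the scatter), showing that this place needs no aryl group to reach the lower numbers of the set, while methyl in place of 4-methylphenyl gives only a 1.6-fold lower number from compound 1 to compound 4 (0.20 log units; within the scatter), so the change is beyond the scatter from compound 2 alone. The step of a 1.0-fold lower number from compound 3 to compound 4 (0.01 log units; within the scatter) shows that hydrogen in place of ethoxycarbonyl on the saturated chain carbon leaves the two compounds indistinguishable, so the ester adds nothing that can be detected here. No evidence is available to explain these steps.

From the compounds shown here alone, what an amine, a carboxylic acid or a longer alkyl chain on this carbon would do remains open. Going by these compounds, it is also open whether any group here can move the number by more than these modest steps.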